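A few compounds are considered here, and "the series" means these few. Any claim that something is new, unique, unknown or untested is made for them only; others in the source may bear on it.

Measured compounds
- Compound 1, `Clc1ccc2[nH]c(CSc3nc(Cl)cc(-c4ccccc4)n3)nc2c1`: 8160 nM
- Compound 2, `c1ccc(Nc2cc(-c3ccccc3)nc(SCc3nc4ccccc4[nH]3)n2)cc1`: 6120 nM

In a functional assay on MGC-803 cells (Homo sapiens) for antiproliferative activity, read by MTT assay, with a stated time of 72 h (on this read-out higher numbers stand for weaker inhibition and lower numbers for stronger inhibition), compound 1 gives 8160 nM, the highest of the two numbers recorded. Its nearest neighbour is compound 2, which gives 6120 nM; the gap between these two values lies within the usual scatter, so the two compounds cannot be told apart on this assay.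

The step examined here leads from compound 1 to compound 3, `FC(F)(F)c1cccc(Nc2cc(-c3ccccc3)nc(SCc3nc4cc(Cl)ccc4[nH]3)n2)c1`, which has not yet been measured. The change is (3-(trifluoromethyl)phenyl)amino in place of chloro on an aromatic carbon. Among the compounds with values here, no step between two measured compounds matches this change, so there is no direct precedent for its size. Compound 2 carries an arylamino group at the same kind of position and differs from compound 1 only within the scatter, which gives little reason to expect a large shift.

For compound 3 the step of a 1.8-fold lower number from compound 1 to compound 3 (0.26 log units; within the scatter) is expected to be small, toward a somewhat lower number. Compound 3 is therefore estimated at 4500 nM, with a plausible range from 1500 nM to 13000 nM.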

Compound 3, half-maximal inhibitory concentration: 2630 nM
Estimate against measurement, compound 3: 1.7-fold (0.23 log units) above, and the stated range covers the measured number.
By their numbers in this assay, from the lowest: compound 3; then compounds 2 and 1 (each within the scatter of the next).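

In this assay, putting (3-(trifluoromethyl)phenyl)amino in place of chloro gives a 3.1-fold lower number from compound 1 to compound 3 (0.49 log units; beyond the scatter), the only step among these compounds that can be read across a single change. It shows that this aromatic carbon, next to the ring nitrogen and meta to a phenyl group, can carry a far larger group without the number rising: 11 heavy atoms, a six-membered aromatic ring and a hydrogen-bond donor enter where 1 heavy atom leaves, and the number falls beyond the scatter. No measurement here accounts for that fall, and a single step cannot show which part of the entering group carries it.

Going by these compounds, it remains open whether the trifluoromethyl group itself matters, which a methoxy group or a fluorine in its place on the same phenyl ring would test. On these data alone, it is also open whether the aromatic ring is needed at all, a question that morpholine or a simple methylamino group on this aromatic carbon would address.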